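The source may hold more compounds than are shown below. What is called first, only, known or untested is meant among the compounds shown, and "the series" means these compounds.

Measured in a functional assay on BGC-823 cells (Homo sapiens) for inhibition, read by MTT assay, with a stated time of 72 h; on this read-out higher numbers stand for weaker inhibition and lower numbers for stronger inhibition:
- Compound 1 `Cc1nc2nc(SCc3ccc(Cl)cc3)nn2c(N2CC[C@@H](C)[C@@H](N(C)c3ncnc4[nH]ccc34)C2)c1C`: > 100000 nM
- Compound 2 `Cc1cc(N2CC[C@@H](C)[C@@H](N(C)c3ncnc4[nH]ccc34)C2)n2nc(SCc3csc4ccc(Cl)cc34)nc2n1`: > 100000 nM

Compound 2 gives > 100000 nM, which is a limit of the assay and not a number. So far the picture comes down to the limit of > 100000 nM in this assay, at which 2 of the 2 values shown sit. With no exact values, neither compound can be ranked against the other.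

Compound 3 `Cc1ccc(CSc2nc3nc(C)cc(N4CC[C@@H](C)[C@@H](N(C)c5ncnc6[nH]ccc56)C4)n3n2)cc1` has 4-methylphenyl in place of 5-chloro-1-benzothiophen-3-yl on a saturated chain carbon bound to a sulfur. Among the compounds with values here, no measured pair shows what a change of this kind does. An expectation can therefore lean only on (the limit of > 100000 nM in this assay, at which 2 of the 2 values shown sit).

The expected step, a number no higher from compound 2 to compound 3 (the limit leaves the size open), is none beyond the scatter in this assay, and another limit is the likeliest report. For compound 3 the estimated value is 100000 nM, with an expected range of 40000 nM to 300000 nM.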

Compound 3, half-maximal inhibitory concentration: 69500 nM
Compound 3: middle estimate off by 1.4-fold (0.16 log units), on the high side, within the range that was stated.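

Within the data shown here, compound 3 is the first compound here with an exact number in this assay, which shows that a group on this saturated chain carbon bound to a sulfur can give a measurable reading and not only a limit. Placing 4-methylphenyl there in place of 5-chloro-1-benzothiophen-3-yl gives an at least 1.4-fold lower number from compound 2 to compound 3 (0.15 log units; that floor lies within the scatter), so the change cannot be called a real gain, since the true size of the step stays hidden behind a limit. Exact readings therefore remain the exception in this small set: the limit of > 100000 nM in this assay, at which 2 of the 3 values shown sit.

From the compounds shown here alone, whether an amine or a carboxylic acid in place of 4-methylphenyl at this position would shift the number beyond the scatter remains open. Also open, going by these compounds, is whether any such group could bring this shared core out of the high range seen so far.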